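Removing One Fluoro: What Compound 4 May Show

The source may hold more compounds than are shown below. What is called first, only, known or untested is meant among the compounds shown, and "the series" means these compounds.

Compound 1 is `Cc1cc(NC(=O)Nc2ccc(F)c(F)c2)c2ccccc2n1`. In an ADME assay on BJ cells (Homo sapiens) for cytotoxicity, with a stated time of 72 h (a higher number here means that more compound is needed for the effect, a lower number that less compound is needed), compound 1 gives a limit of > 25000 nM.
Compound 2 is `Cc1cc(NC(=O)Nc2cccc(C(C)(C)C)c2)c2ccccc2n1`. In this assay compound 2 gives a limit of > 25000 nM.
Compound 3 is `Cc1cc(NC(=O)Nc2cc(F)cc(F)c2)c2ccccc2n1`. In this assay compound 3 gives a limit of > 25000 nM.

Compound 3 therefore stands on no number of its own but on a limit of the assay, and it stands there together with the two other compounds: the limit of > 25000 nM in this assay, at which 3 of the 3 values shown sit. No pair among these three differs in only one place, so the three values show nothing more than that none of the compounds reached a measurable effect within the range tested.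

Compound 4 is `Cc1cc(NC(=O)Nc2cccc(F)c2)c2ccccc2n1`, not yet measured in this assay. It differs from compound 3 as follows: hydrogen in place of fluoro on an aromatic carbon. The group that leaves is a fluoro on an aromatic carbon of a six-membered aromatic ring of carbon only, and a hydrogen enters in its place.

With compound 1, compound 2 and compound 3 all resting at the same limit, the account expects no step beyond the usual scatter, in either direction; the step that the limit leaves unreadable from compound 3 to compound 4 is expected to be essentially none. For compound 4 the estimate in this assay is 40000 nM, within a range from 15000 nM to 120000 nM, and most likely the assay will again return only a limit.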

Compound 4, half-maximal effective concentration in the BJ assay: > 25000 nM
Compound 4: no number, only a limit; the forecaster's own chance of this, stated with the estimate: 85%; the middle value does not contradict the limit.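

In the BJ assay compound 4 gives > 25000 nM, a limit of the assay and not a number. No step from compound 1, compound 2 or compound 3 to compound 4 can be read, as all four rest on the same limit: the limit of > 25000 nM in the BJ assay, at which 4 of the 4 values shown sit.

In a physicochemical assay for solubility, at pH 7.4 (on this read-out higher numbers stand for higher solubility and lower numbers for lower solubility), compound 3 gives 300 nM and compound 4 gives 100 nM. The compounds shown leave open what concentration, if any, would bring a measurable effect in the BJ assay.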